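The source may hold more compounds than are shown below. What is called first, only, known or untested is meant among the compounds shown, and "the series" means these compounds.

Working notes on the series.

Three compounds share the core shown in compound 1 `CCCCNc1nc(C(F)(F)F)ccc1CNC(=O)C(C)c1ccc(NS(C)(=O)=O)c(F)c1` and differ only in the group on the nitrogen attached to the aromatic ring. In a functional assay on CHO-K1 cells for antagonist activity at transient receptor potential cation channel subfamily V member 1 (Homo sapiens), read by FLIPR (on this read-out lower numbers stand for stronger inhibition and higher numbers for weaker inhibition), compound 1 gives 9.1 nM. Compound 2 `CC1CCC(Nc2nc(C(F)(F)F)ccc2CNC(=O)C(C)c2ccc(NS(C)(=O)=O)c(F)c2)CC1` carries a 4-methylcyclohexyl there and gives 27.2 nM in this assay; the step is a 3.0-fold higher number from compound 1 to compound 2 (0.48 log units; beyond the scatter). Compound 3 `CC(C(=O)NCc1ccc(C(F)(F)F)nc1Nc1ccccc1)c1ccc(NS(C)(=O)=O)c(F)c1` carries a phenyl and gives 59.6 nM in this assay, the highest number of the three, with a 6.5-fold higher number from compound 1 to compound 3 (0.82 log units; beyond the scatter) and a 2.2-fold higher number from compound 2 to compound 3 (0.34 log units; beyond the scatter).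

Compound 4 `Cc1ccc(Nc2nc(C(F)(F)F)ccc2CNC(=O)C(C)c2ccc(NS(C)(=O)=O)c(F)c2)cc1C` is not yet measured. The change from compound 3 is 3,4-dimethylphenyl in place of phenyl on a nitrogen on an aromatic ring. Among the compounds with values here, no measured step touches a substituent on that phenyl; the three steps only compare butyl, 4-methylcyclohexyl and phenyl against one another, and all three were modest. They show that the phenyl sits at the weak end of this small set, but nothing on what methyl groups placed on it do. The expected step from compound 3 is therefore taken as small, in either direction, with a wide range. The step expected as a working assumption is a 1.3-fold lower number from compound 3 to compound 4 (0.12 log units; within the scatter). The estimate for compound 4 in this assay is 45 nM, expected to fall between 12 nM and 170 nM.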

Compound 4, inhibition constant: 39.3 nM
Estimate against measurement, compound 4: 1.1-fold (0.06 log units) above; measured number inside the range.
By their numbers in this assay, from the lowest: compound 1; then compounds 2, 4 and 3 (each within the scatter of the next, the first and the last beyond it).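

Placing methyl groups on the phenyl gives a 1.5-fold lower number from compound 3 to compound 4 (0.18 log units; within the scatter) in this assay, and replacing 4-methylcyclohexyl with 3,4-dimethylphenyl gives a 1.4-fold higher number from compound 2 to compound 4 (0.16 log units; within the scatter); 3,4-dimethylphenyl therefore cannot be told apart from either group on this nitrogen, even though phenyl and 4-methylcyclohexyl are themselves separated by more than the scatter. Against butyl the result is different, with a 4.3-fold higher number from compound 1 to compound 4 (0.64 log units; beyond the scatter), so compound 1 now stands beyond the scatter from all three other compounds and has the strongest inhibition in this set. Nothing available accounts for these numbers or for the separation of butyl from the three ring-bearing groups.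

Still open, from the compounds shown here alone, is whether a chlorine, a methoxy group or a carboxylic acid on the phenyl would give a number clearly different from that of phenyl itself, since methyl groups are the only substituents on that ring here. Also open, going by these compounds, is how far the butyl result extends: propyl, a longer chain such as hexyl, and unsubstituted cyclohexyl on the same nitrogen would each help show whether the open chain is what sets compound 1 apart.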